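Swapping a hexyl chain for 4-methoxyphenyl

This account rests on a few compounds, and the source may have more. Where it says the series, first, only, none or still open, it means among the compounds named here.

Measured so far in a functional assay on HeLa cells (Homo sapiens) for cytotoxicity, read by WST assay, with a stated time of 48 h; on this read-out lower numbers stand for stronger inhibition and higher numbers for weaker inhibition 
- compound 1 `COc1ccc([C@H](O)[C@H]2CO[C@@H](c3ccc(OC)c(OC)c3)[C@H](C/C=C/c3ccccc3)C2)cc1OC` gives 16100 nM 
- compound 2 `CCCCCC/C=C/C[C@H]1C[C@@H]([C@@H](O)c2ccccc2)CO[C@@H]1c1ccccc1` gives 7400 nM 
- compound 3 `COc1ccc(/C=C/C[C@H]2C[C@@H]([C@@H](O)c3ccccc3)CO[C@@H]2c2ccc(OC)c(OC)c2)cc1OC` gives 15500 nM 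

Compound 2 has the lowest number of the three, at 7400 nM. Compound 3 and compound 1 both sit higher, each only slightly beyond the usual scatter of repeated measurements.

The next molecule is compound 4 `COc1ccc(/C=C/C[C@H]2C[C@@H]([C@@H](O)c3ccccc3)CO[C@@H]2c2ccccc2)cc1`. It differs from compound 2 in one place: 4-methoxyphenyl in place of hexyl on a double-bonded chain carbon bound to a double-bonded chain carbon. In words, 4-methoxyphenyl replaces hexyl on a double-bonded chain carbon bound to a double-bonded chain carbon.

Among the compounds with values here, no measured pair isolates this swap, so any expectation is indirect. Compound 3, at 15500 nM, and compound 1, at 16100 nM, also carry an aromatic ring on that chain, though they differ from compound 2 elsewhere too. A small move to a higher number in this assay therefore seems likely.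

The estimated change is a 1.8-fold higher number from compound 2 to compound 4 (0.24 log units; within the scatter).

Compound 4 is estimated at 13000 nM, with an expected range from 6500 nM to 26000 nM.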

Compound 4, half-maximal inhibitory concentration: 8300 nM
Compound 4: middle estimate off by 1.6-fold (0.19 log units), on the high side; low and high end bracket the measured number.
By their numbers in this assay, from the lowest: compounds 2, 4, 3 and 1 (each within the scatter of the next, the first and the last beyond it).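

Within the data shown here, this is the first pair in which only this place changes. In this assay, replacing hexyl with 4-methoxyphenyl on a double-bonded chain carbon bound to a double-bonded chain carbon gives a 1.1-fold higher number from compound 2 to compound 4 (0.05 log units; within the scatter), so the assay does not separate the two groups here, even though the entering group brings an aromatic ring and a hydrogen-bond acceptor that hexyl lacks. Nothing available explains why these two different groups read alike.

Going by these compounds, whether this tolerance extends to other kinds of group at this place, such as an amine, a carboxylic acid or a longer chain, remains open. This single pair also speaks only for the core of compound 2, so the same swap could read differently on another core.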